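The compounds below may be only part of what the source reports. "The series", "measured", "known", "first", "only" and "open" are said of these compounds alone.

Of the compounds shown here, three built on one shared core have been measured in a functional assay on HeLa cells (Homo sapiens) for antiproliferative activity, read by sulforhodamine B assay; a higher number here means a weaker inhibitor, a lower number a stronger inhibitor. Compound 1 `CC(C)/C(=N\Nc1nc2ccccc2o1)c1ccccn1` gives 185 nM. Compound 2 `C/C(=N\Nc1nc2ccccc2o1)c1nccnc1C` gives 1860 nM, and compound 3 `C/C(=N\Nc1nc2ccccc2o1)c1cnc(C)cn1` gives 370 nM. Compound 1 therefore shows the lowest number of the three. Its nearest neighbour, compound 3, sits within the usual scatter of such measurements, so the two cannot be told apart on these data, while compound 2 lies clearly beyond the scatter and is a weaker inhibitor than compound 1.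

Compound 4 `CC(C)(C)/C(=N\Nc1nc2ccccc2o1)c1ccccn1` has not yet been measured. It differs from compound 1 in one place: methyl in place of hydrogen on a saturated chain carbon bound to a carbon with a double bond to nitrogen and two saturated chain carbons. Going by the values given here, no pair of measured compounds shows this change, so the data give no direct guide to its effect. The expectation is that the step of a 1.6-fold higher number from compound 1 to compound 4 (0.21 log units; within the scatter) stays within the scatter or weakens the inhibitor only slightly. Compound 4 is accordingly estimated at 300 nM, with a range from 100 nM to 1000 nM.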

Compound 4, half-maximal inhibitory concentration: > 10000 nM
Compound 4: no number, only a limit; the forecaster's own chance of this, stated with the estimate: 5%; at least 33-fold (1.52 log units) between middle value and limit.
By their numbers in this assay, from the lowest: compounds 1 and 3 (each within the scatter of the next); then compound 2. At a limit, above all of these: compound 4.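

Replacing isopropyl with tert-butyl, a change of a single methyl on a saturated chain carbon, produces an at least 54-fold higher number from compound 1 to compound 4 (1.73 log units; beyond the scatter) in this assay. Compound 4 has no exact value here, only a limit: the limit of > 10000 nM in this assay, at which 1 of the 4 values shown sits. Going by these compounds alone, no earlier pair isolated a change at this place, so this step gives the first direct sign that the group here can matter greatly, and that one added methyl can be enough to take the antiproliferative activity of compound 1 out of the range that can be read.

The step on its own does not explain why this methyl has so large an effect. It also leaves open whether an ethyl group, a cyclopropyl ring or a longer straight chain at this place would keep the activity of compound 1 or lose it as well.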